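One Group Swapped on a Shared Core

The compounds below may be only part of what the source reports. "The series", "measured", "known", "first", "only" and "open" are said of these compounds alone.

In a functional assay on ECa-109 cells for inhibition, with ECa-109 cell line (Homo sapiens) as the target, read by sulforhodamine B assay (a lower number here means a stronger inhibitor, a higher number a weaker inhibitor), compound 1 `O=C1C(Nc2ccc(Br)cc2)=CC(=O)c2c1nc1n2[C@H]2OC[C@@H](O)[C@H]2OC1` reads 1980 nM while compound 2 `O=C1C=C(Nc2ccccc2F)C(=O)c2c1nc1n2[C@H]2OC[C@@H](O)[C@H]2OC1` reads 2760 nM and so stands level with it, since the two values lie within the usual scatter of repeat measurements. Compound 3 `CCOc1ccc(NC2=CC(=O)c3nc4n(c3C2=O)[C@H]2OC[C@@H](O)[C@H]2OC4)cc1` keeps the core of compound 2 and brings 4-ethoxyphenyl in place of 2-fluorophenyl on an amine nitrogen in a single change: 4-ethoxyphenyl in place of 2-fluorophenyl on an amine nitrogen. Among the measured compounds shown here, no measured pair differs in one place only, so the data offer no direct guide to this swap. Compound 1 at 1980 nM and compound 2 at 2760 nM carry different groups on that nitrogen yet sit within the scatter of each other, so no step beyond the scatter is expected in this assay for this swap. The expected change is a step of a 1.3-fold lower number from compound 2 to compound 3 (0.10 log units; within the scatter) and nothing larger. Compound 3 is estimated at 2200 nM with 800 nM to 6000 nM as its expected range.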

Compound 3, half-maximal inhibitory concentration: 3210 nM
Compound 3: middle estimate off by 1.5-fold (0.16 log units), on the low side; the range from low to high includes it.
By their numbers in this assay, from the lowest: compounds 1, 2 and 3 (each within the scatter of the next).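

Among the compounds shown here, this is the first direct reading of a single change on this amine nitrogen: in this assay, 4-ethoxyphenyl in place of 2-fluorophenyl gives a 1.2-fold higher number from compound 2 to compound 3 (0.07 log units; within the scatter). So, in this assay, the nitrogen takes the larger 4-ethoxyphenyl, which brings a hydrogen-bond acceptor that 2-fluorophenyl lacks, with no change that can be told from repeat-measurement noise. No separate measurement is available to help interpret this result.

Going by these compounds, because the fluorine leaves and the ethoxy group enters in one step, their separate contributions remain unknown, and unsubstituted phenyl would be needed to separate them. On these data alone, it also remains open whether a group of another kind on this nitrogen, such as cyclohexyl or a phenyl ring carrying a carboxylic acid, would shift the number beyond the scatter.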